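The compounds below may be only part of what the source reports. "The series", "measured", "known", "first", "only" and "open" are said of these compounds alone.

Compound 3 `CO[C@@H]1[C@@H](OC)[C@H](c2ccccc2)O[C@@H]2CO[C@@H](c3ccco3)O[C@@H]12` carries a furan-2-yl group on the shared core, and in a functional assay on HEL cells (Homo sapiens) for cytotoxicity (a higher number here means that more compound is tolerated, a lower number that less compound is tolerated), compound 3 is recorded as "not determined" (no result reported), so the step has no measured starting point. Among the measured compounds shown here, two relatives with free hydroxyl groups offer the only guidance. Compound 1 `O[C@@H]1[C@@H](O)[C@H](c2ccccc2)O[C@@H]2CO[C@@H](c3ccc(Cl)cc3)O[C@@H]12` gives > 50 ug/mL, which is a limit of the assay. Compound 2 `O[C@@H]1[C@@H](O)[C@H](c2ccccc2)O[C@@H]2CO[C@@H](c3ccc(C(F)(F)F)cc3)O[C@@H]12` gives 35 ug/mL. Compound 4 `CO[C@@H]1[C@@H](OC)[C@H](c2ccccc2)O[C@@H]2CO[C@@H](C3CCCCC3)O[C@@H]12` differs from compound 3 as follows: cyclohexyl in place of furan-2-yl on a saturated ring carbon. For the measured compounds named here, the only measured step, an at least 1.4-fold lower number from compound 1 to compound 2 (0.15 log units; that floor lies within the scatter), concerns other groups and bears only loosely on this change, so no step beyond the scatter is expected in this assay. Compound 4 is estimated at 40 ug/mL, with an expected range of 15 ug/mL to 100 ug/mL.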

Compound 4, half-maximal cytotoxic concentration: 28 ug/mL
Compound 4: the middle estimate sits 1.4-fold (0.15 log units) above what was measured; measured number inside the range.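

Among the compounds shown here, compound 3 has no reported result in this assay, so no step from compound 3 to compound 4 can be read. The compounds shown leave open how furan-2-yl and cyclohexyl compare on the shared core, and how large the step from compound 1 to compound 2 truly is, given: the limit of > 50 ug/mL in this assay, at which 1 of the 4 values shown sits.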